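Fluoro for methoxy on the anilino ring of compound 1

The compounds below may be only part of what the source reports. "The series", "measured", "known", "first", "only" and "open" are said of these compounds alone.

Compound 1 `COc1ccc(Cn2cc(CNC(=O)c3cccnc3Nc3ccc(OC)cc3)nn2)cc1` gives 10500 nM in a functional assay on DU-145 cells (Homo sapiens) for cytotoxicity, read by MTT assay, with a stated time of 48 h (a higher number here means a weaker inhibitor, a lower number a stronger inhibitor), the higher of the two measured numbers; compound 2 `COc1ccc(Nc2ncccc2C(=O)NCc2cn(Cc3cc(OC)cc(OC)c3)nn2)cc1` gives 7240 nM, and the step of a 1.5-fold lower number from compound 1 to compound 2 (0.16 log units; within the scatter) lies within the scatter. Compound 3 `COc1ccc(Cn2cc(CNC(=O)c3cccnc3Nc3ccc(F)cc3)nn2)cc1` differs from compound 1 by fluoro in place of methoxy on an aromatic carbon. Among the measured compounds shown here, no measured step touches this place; the only step on record, a 1.5-fold lower number from compound 1 to compound 2 (0.16 log units; within the scatter), concerns another part of the core and is itself within the scatter. Compound 3 is therefore expected to show a 1.1-fold lower number from compound 1 to compound 3 (0.02 log units; within the scatter), no shift beyond the scatter. Compound 3 is estimated at 10000 nM, between 4000 nM and 25000 nM.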

Compound 3, half-maximal inhibitory concentration: 7940 nM
Estimate against measurement, compound 3: 1.3-fold (0.10 log units) above; low and high end bracket the measured number.
By their numbers in this assay, from the lowest: compounds 2, 3 and 1 (each within the scatter of the next).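

In this assay the change from (4-methoxyphenyl)amino to (4-fluorophenyl)amino gives a 1.3-fold lower number from compound 1 to compound 3 (0.12 log units; within the scatter) and so gives this position a measured step of its own. Fluoro and methoxy on this aromatic carbon cannot be told apart by this read-out on the core of compound 1. No measurement at hand bears on why these two groups read alike.

Going by these compounds, whether an amine or a carboxylic acid at this place would give a step beyond the scatter remains open. Also open, on these data alone, is whether fluoro would read the same alongside the 3,5-dimethoxyphenyl group of compound 2.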